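Swapping Isopropyl for Hydrogen on Compound 2

A few compounds are considered here, and "the series" means these few. Any claim that something is new, unique, unknown or untested is made for them only; others in the source may bear on it.

In a functional assay on HCT-116 cells (Homo sapiens) for cytotoxicity, read by MTT assay, with a stated time of 3 days (a higher number here means a weaker inhibitor, a lower number a stronger inhibitor), compound 1 `CC(C)(C)c1cc2c(N/N=C/c3ccc(CN)cc3)ncnc2s1` gives 0.334 ug/mL as its result, and compound 2 `CC(C)N1Cc2ccc(/C=N/Nc3ncnc4sc(C(C)(C)C)cc34)cc2C1` gives 0.206 ug/mL as its result. These two numbers lie within the usual scatter of repeated measurements, so compound 2 stands level with compound 1 and the pair cannot be ranked. The change hydrogen in place of isopropyl on an amine nitrogen in a ring turns compound 2 into compound 3 `CC(C)(C)c1cc2c(N/N=C/c3ccc4c(c3)CNC4)ncnc2s1` and puts hydrogen in place of isopropyl on an amine nitrogen in a ring. Within the data shown here, no measured pair shows this change on its own, so its effect cannot be read directly from the data. Among the measured compounds shown here, with only two close values to go on, a small shift toward a slightly higher number is expected, and nothing beyond the scatter. The estimated step is a 1.3-fold higher number from compound 2 to compound 3 (0.12 log units; within the scatter) in this assay and would stay within that scatter. For compound 3 the expected value is 0.27 ug/mL with a range from 0.11 ug/mL to 0.65 ug/mL as the estimate.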

Compound 3, half-maximal inhibitory concentration: 0.111 ug/mL
For compound 3 the middle estimate is 2.4-fold (0.39 log units) above the measured one, and the stated range covers the measured number.
By their numbers in this assay, from the lowest: compounds 3, 2 and 1 (each within the scatter of the next, the first and the last beyond it).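

Among these compounds, replacing the isopropyl on the amine nitrogen with hydrogen is the first single change that can be read directly at this position, and in this assay it gives a 1.9-fold lower number from compound 2 to compound 3 (0.27 log units; within the scatter). On this nitrogen of the five-membered ring, then, the isopropyl and a plain hydrogen cannot be told apart in these cells, so the isopropyl is not needed for the cytotoxicity seen with compound 2. Nothing measured here bears on the reason for this result.

The compounds shown leave open whether a group of another kind on this nitrogen, such as an acetyl or a benzyl, would also stay level with compound 3. They also leave open whether hydrogen and isopropyl would read alike in any test other than this assay.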